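Sulfonyl for ether in the side chain of compound 1

A few compounds are considered here, and "the series" means these few. Any claim that something is new, unique, unknown or untested is made for them only; others in the source may bear on it.

Measured so far:
- compound 1 `NCCOCCOc1ccc([C@H]2CC[C@]3(CC2)OOC2(O3)C3CC4CC(C3)CC2C4)cc1`; in an ADME assay on microsomes from liver (Homo sapiens) for metabolic stability, read by LC-MS, tested at 1 uM (a higher number here means faster removal of the compound, a lower number slower removal), compound 1 gives < 7 mL.min-1.g-1, a limit of the assay.
- compound 2 `CC(C)(O)CN1CCC(Oc2ccc([C@H]3CC[C@]4(CC3)OOC3(O4)C4CC5CC(C4)CC3C5)cc2)CC1`; in this assay compound 2 gives 18 mL.min-1.g-1.
- compound 3 `NC1CCN(S(=O)(=O)c2ccc([C@H]3CC[C@]4(CC3)OOC3(O4)C4CC5CC(C4)CC3C5)cc2)CC1`; in this assay compound 3 gives < 7 mL.min-1.g-1, a limit of the assay.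

Compound 1 sits at the limit of < 7 mL.min-1.g-1 in this assay, at which 2 of the 3 values shown sit, so only a limit is known for it, and the step that the two limits leave unreadable from compound 1 to compound 3 is for that reason not readable. Against compound 2 the step is an at least 2.5-fold higher number from compound 1 to compound 2 (0.41 log units; beyond the scatter), and from compound 2 to compound 3 it is an at least 2.5-fold lower number from compound 2 to compound 3 (0.41 log units; beyond the scatter).

Compound 4 `NCCS(=O)(=O)CCOc1ccc([C@H]2CC[C@]3(CC2)OOC2(O3)C3CC4CC(C3)CC2C4)cc1` differs from compound 1 by (2-aminoethyl)sulfonyl in place of 2-aminoethoxy on a saturated chain carbon, two bonds along the chain from an oxygen on an aromatic ring. Going by the values given here, no measured step reproduces this change: the move to compound 3 also brings in a sulfonyl, but that step cannot be read. Going by these compounds, the side chain of compound 1 stays open and carries the same terminal amine, so compound 4 is expected to remain where compound 1 lies, with a step that the limit leaves unreadable from compound 1 to compound 4, a step expected to stay within the scatter. Compound 4 is therefore estimated at 6 mL.min-1.g-1, between 3 mL.min-1.g-1 and 13 mL.min-1.g-1, most likely again reported as a limit.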

Compound 4, intrinsic clearance in microsomes: 9 mL.min-1.g-1
The estimate for compound 4 lay 1.5-fold (0.18 log units) below the measured number; low and high end bracket the measured number.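

In this assay compound 4 gives a number and not a limit, so this open side chain now has a readable value: 9 mL.min-1.g-1. Putting (2-aminoethyl)sulfonyl in place of 2-aminoethoxy on this saturated chain carbon gives an at least 1.2-fold higher number from compound 1 to compound 4 (0.10 log units; that floor lies within the scatter), and that step is only a floor, because compound 1 stands at a limit of the assay: the limit of < 7 mL.min-1.g-1 in this assay, at which 2 of the 4 values shown sit. Compound 3 gives the same kind of floor, with an at least 1.2-fold higher number from compound 3 to compound 4 (0.10 log units; that floor lies within the scatter), whereas the comparison with compound 2 gives a full reading, a 2.0-fold lower number from compound 2 to compound 4 (0.30 log units; within the scatter), so compound 4 does not show the gap beyond the scatter that separates compound 2 from compound 1 and compound 3.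

Going by these compounds, the true size of the change from compound 1 to compound 4 remains unknown, and the step from compound 1 to compound 3 cannot be read. The compounds shown also leave open how the sulfonyl chain reads in this assay when its terminal primary amine gives way to a dimethylamine or a carboxylic acid, or when a longer chain separates the sulfonyl from that amine.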